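Swapping the Carboxy for 2-Bromoethyl on Compound 2

A few compounds are considered here, and "the series" means these few. Any claim that something is new, unique, unknown or untested is made for them only; others in the source may bear on it.

- Compound 1 `CCCCCC[C@@]1(C)SC(=O)C=C1OCC(=O)OCC`: 14.2 ug/mL
- Compound 2 `CCCCCC[C@@]1(C)SC(=O)C=C1OCC(=O)NCC(=O)O`: 6.6 ug/mL

Among the compounds with values here, in a functional assay on MCF7 cells (Homo sapiens) for inhibition (on this read-out higher numbers stand for weaker inhibition and lower numbers for stronger inhibition), compound 2 gives 6.6 ug/mL, the lower of the two numbers so far. Compound 3 `CCCCCC[C@@]1(C)SC(=O)C=C1OCC(=O)NCCCBr` differs from it in one place: 2-bromoethyl in place of carboxy on a saturated chain carbon bound to an amide-type nitrogen. In words, 2-bromoethyl stands in place of carboxy on a saturated chain carbon bound to an amide-type nitrogen. Within the data shown here, only one measured step bears on this change, and it is modest: a 2.2-fold lower number from compound 1 to compound 2 (0.33 log units; beyond the scatter). A single step gives weak guidance, so a similarly modest rise in this assay is expected, though its direction is uncertain. The expected step is a 1.5-fold higher number from compound 2 to compound 3 (0.18 log units; within the scatter). The estimate for compound 3 is 10 ug/mL, with an expected range from 4 ug/mL to 25 ug/mL.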

Compound 3, half-maximal inhibitory concentration: 6.7 ug/mL
Estimate against measurement, compound 3: 1.5-fold (0.17 log units) above; measured number inside the range.
By their numbers in this assay, from the lowest: compounds 2 and 3 (each within the scatter of the next); then compound 1.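

In this assay the carboxy group can give way to 2-bromoethyl on this chain carbon with a 1.0-fold higher number from compound 2 to compound 3 (0.01 log units; within the scatter), so in this pair the number does not depend on the carboxy group. With a 2.1-fold lower number from compound 1 to compound 3 (0.33 log units; beyond the scatter) as well, the drop from the ethoxy compound now appears with two different amide side chains, not only with carboxymethyl. Nothing shown gives a reason for either result. The compounds shown leave open what a plain propyl chain, an amine or a longer chain would give at this place, and so whether the bromine itself matters.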